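Trimming a Pyridine Substituent: From Azetidinyl Carbinol to Tertiary Alcohol

This account rests on a few compounds, and the source may have more. Where it says the series, first, only, none or still open, it means among the compounds named here.

Compound 1 `O=C1O[C@@H](Cn2ccnn2)CN1c1ccc(-c2ccc(CO)nc2)c(F)c1`: 4800 nM
Compound 2 `CN1CCN(CCCC(=O)c2ccc(-c3ccc(N4C[C@H](Cn5ccnn5)OC4=O)cc3F)cn2)CC1`: 10500 nM
Compound 3 `O=C1O[C@@H](Cn2ccnn2)CN1c1ccc(-c2ccc(C(O)C3CNC3)nc2)c(F)c1`: 58000 nM

In an assay for inhibition of Amine oxidase [flavin-containing] A (Homo sapiens) (on this read-out lower numbers stand for stronger inhibition and higher numbers for weaker inhibition), compound 3 gives the highest number of the three, with a 12-fold higher number from compound 1 to compound 3 (1.08 log units; beyond the scatter) and a 5.5-fold higher number from compound 2 to compound 3 (0.74 log units; beyond the scatter) both beyond the scatter. Compound 4 `CC(C)(O)c1ccc(-c2ccc(N3C[C@H](Cn4ccnn4)OC3=O)cc2F)cn1` differs from compound 3 by 1-hydroxy-1-methylethyl in place of (azetidin-3-yl)(hydroxy)methyl on an aromatic carbon. The step bearing most on this change is a 12-fold higher number from compound 1 to compound 3 (1.08 log units; beyond the scatter), where attaching the azetidine ring to the hydroxymethyl carbon of compound 1 cost a large amount; compound 4 removes that ring again while adding two methyl groups to the same carbon. Because of a 12-fold higher number from compound 1 to compound 3 (1.08 log units; beyond the scatter), a move back toward the number of compound 1 is expected, as an 8.3-fold lower number from compound 3 to compound 4 (0.92 log units; beyond the scatter). Compound 4 is therefore estimated at 7000 nM, with a range from 2500 nM to 20000 nM.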

Compound 4, inhibition constant: 6000 nM
Estimate against measurement, compound 4: 1.2-fold (0.07 log units) above; low and high end bracket the measured number.
By their numbers in this assay, from the lowest: compounds 1, 4 and 2 (each within the scatter of the next, the first and the last beyond it); then compound 3.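

In this assay the change from (azetidin-3-yl)(hydroxy)methyl to 1-hydroxy-1-methylethyl gives a 9.7-fold lower number from compound 3 to compound 4 (0.99 log units; beyond the scatter) and so recovers nearly all that compound 3 lost. At this position, next to the ring nitrogen, two methyl groups on the hydroxyl-bearing carbon cost nothing measurable, as a 1.3-fold higher number from compound 1 to compound 4 (0.10 log units; within the scatter) lies within the scatter, and a 1.8-fold lower number from compound 2 to compound 4 (0.24 log units; within the scatter) does too. Still open, going by these compounds, is whether the azetidine's nitrogen or its ring accounts for the high number of compound 3; a cyclobutyl group on that carbon would separate the two. No measured evidence here explains the gap between compound 3 and compound 4.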